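Replacing pyrrolidin-1-yl with diethylamino: what to expect

This account rests on a few compounds, and the source may have more. Where it says the series, first, only, none or still open, it means among the compounds named here.

In a functional assay on A549 cells (Homo sapiens) for cytotoxicity, read by MTT assay, with a stated time of 48 h (a higher number here means a weaker inhibitor, a lower number a stronger inhibitor), compound 3 `COc1c(OCCCCN2CCCC2)cc(O)c2c(=O)cc(-c3ccccc3)oc12` gives 1530 nM. Compound 1 `COc1c(OCCCCN2CCNCC2)cc(O)c2c(=O)cc(-c3ccccc3)oc12` gives 1740 nM, within the usual scatter of compound 3. Compound 2 `COc1c(OCc2nc3ccccc3[nH]2)cc(O)c2c(=O)cc(-c3ccccc3)oc12` is reported only as a limit, > 100000 nM.

Compound 4 `CCN(CC)CCCCOc1cc(O)c2c(=O)cc(-c3ccccc3)oc2c1OC` differs from compound 3 by one change: diethylamino in place of pyrrolidin-1-yl on a saturated chain carbon, four bonds along the chain from an oxygen on an aromatic ring. Going by the values given here, the closest precedent is a 1.1-fold lower number from compound 1 to compound 3 (0.06 log units; within the scatter), a swap of piperazin-1-yl for pyrrolidin-1-yl at the same place, and it stayed within the scatter. The large steps, an at least 57-fold higher number from compound 1 to compound 2 (1.75 log units; beyond the scatter) and an at least 65-fold lower number from compound 2 to compound 3 (1.81 log units; beyond the scatter), replace the whole amine-bearing chain end with 1H-benzimidazol-2-yl, a far bigger change. No step beyond the scatter is therefore expected in this assay, only an estimated 1.1-fold higher number from compound 3 to compound 4 (0.05 log units; within the scatter). Compound 4 is expected at about 1700 nM, with an estimated range of 800 nM to 3800 nM.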

Compound 4, half-maximal inhibitory concentration: 1000 nM
The estimate for compound 4 lay 1.7-fold (0.23 log units) above the measured number; the measured number falls inside the stated range.
By their numbers in this assay, from the lowest: compounds 4, 3 and 1 (each within the scatter of the next). At a limit, above all of these: compound 2.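

In this assay, trading the ring of pyrrolidin-1-yl for the open diethylamino group, with the same count of heavy atoms, stays within the scatter: a 1.5-fold lower number from compound 3 to compound 4 (0.18 log units; within the scatter). The swap from piperazin-1-yl also stays within it, a 1.7-fold lower number from compound 1 to compound 4 (0.24 log units; within the scatter), so compounds 1, 3 and 4 read alike whether or not this chain end carries a ring. The large gap to the benzimidazole compound persists, an at least 100-fold lower number from compound 2 to compound 4 (2.00 log units; beyond the scatter), but that step rests on a limit for compound 2: the limit of > 100000 nM in this assay, at which 1 of the 4 values shown sits.

Still open, going by these compounds, is what a chain ending in a hydroxyl group, with no amine, would give. On these data alone, it is also open whether a shorter chain carrying diethylamino would keep these numbers.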